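The source may hold more compounds than are shown below. What is called first, only, known or untested is meant among the compounds shown, and "the series" means these compounds.

Compound 1 `Cc1cc(COc2cccc(Cl)c2)nc(-c2ccccn2)n1` joins its shared core through an oxygen to an aromatic ring that bears a chloro group. In a functional assay on cells for antagonist activity at Free fatty acid receptor 1 (Homo sapiens), read by TR-FRET and inositol phosphate accumulation, with a stated time of 2 h (on this read-out lower numbers stand for stronger inhibition and higher numbers for weaker inhibition), compound 1 gives 398 nM, the only full number shown among the measured compounds. Compound 2 `CC(=O)Nc1cccc(OCc2cc(C)nc(-c3ccccn3)n2)c1` returns no number in this assay but only a limit of > 39800 nM. The step is an at least 100-fold higher number from compound 1 to compound 2 (2.00 log units; beyond the scatter), and the limit of > 39800 nM in this assay, at which 1 of the 2 values shown sits, marks how far that measurement could reach. Compound 3 `Cc1cc(COc2ccc(F)cc2)nc(-c2ccccn2)n1` differs from compound 1 in one place: 4-fluorophenyl in place of 3-chlorophenyl on an oxygen on a saturated carbon. Within the data shown here, no measured step swaps one halogen-bearing ring for another, so the step from compound 1 to compound 2 serves only as a warning that changes at this ring can cost a great deal. For compound 3 a modest weakening is expected, a 2.5-fold higher number from compound 1 to compound 3 (0.40 log units; beyond the scatter). Compound 3 is therefore estimated at 1000 nM in this assay, with a range from 300 nM to 5000 nM.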

Compound 3, half-maximal inhibitory concentration: 631 nM
The estimate for compound 3 lay 1.6-fold (0.20 log units) above the measured number; low and high end bracket the measured number.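

In this assay, 4-fluorophenyl in place of 3-chlorophenyl gives a 1.6-fold higher number from compound 1 to compound 3 (0.20 log units; within the scatter), so this step cannot be told apart from repeat-measurement noise. Compound 2 gave only a warning about this ring, whereas this pair shows that at least one change of the ring's halogen-bearing form leaves the read-out within the scatter. Nothing measured here explains why these two rings read alike.

The step changes both the halogen and its place on the ring, and no compound shown separates the two. Also open, going by these compounds, is how this ring would read with an amine, a carboxylic acid or a methoxy group, and whether such groups would behave more like the halogens of compound 1 and compound 3 or like the acetamido group of compound 2.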